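The source may report more compounds than this note shows. Statements on the series, on what has been measured and on what is new or still open speak of the compounds shown alone.

Working notes on the sulfonyl series in an ADME assay on HEK-293T cells (Homo sapiens) for cytotoxicity, read by MTT assay, with a stated time of 24 h; on this read-out lower numbers stand for higher toxicity in this test and higher numbers for lower toxicity in this test. Compound 1 `Cc1ccc(-c2nn(-c3ccccc3)cc2-c2nc3ccccc3n2S(=O)(=O)c2ccc(Br)cc2)cc1` gives 159000 nM. Compound 2 `Cc1ccc(-c2nn(-c3ccccc3)cc2-c2nc3ccccc3n2S(=O)(=O)c2ccc(C(F)(F)F)cc2)cc1` carries trifluoromethyl in place of bromo on an aromatic carbon, and in this assay compound 2 gives 182000 nM, a step of a 1.1-fold higher number from compound 1 to compound 2 (0.06 log units; within the scatter). The core of compound 3 `O=S(=O)(c1ccc(Br)cc1)n1c(-c2cn(-c3ccccc3)nc2-c2ccc(C(F)(F)F)cc2)nc2ccccc21` differs from that of compound 1 by trifluoromethyl in place of methyl on an aromatic carbon; in this assay compound 3 gives 185000 nM, a step of a 1.2-fold higher number from compound 1 to compound 3 (0.07 log units; within the scatter). Compound 4 `O=S(=O)(c1ccc(C(F)(F)F)cc1)n1c(-c2cn(-c3ccccc3)nc2-c2ccc(C(F)(F)F)cc2)nc2ccccc21` is not yet measured; it differs from compound 3 by trifluoromethyl in place of bromo on an aromatic carbon, the same change as the one already seen, which gave a 1.1-fold higher number from compound 1 to compound 2 (0.06 log units; within the scatter), and the place is described in the same words both times. For compound 4 a step of a 1.1-fold higher number from compound 3 to compound 4 (0.03 log units; within the scatter) in this assay is expected, resting on that earlier step. Compound 4 is estimated at 200000 nM, within 120000 nM to 330000 nM.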

Compound 4, half-maximal cytotoxic concentration: 63200 nM
For compound 4 the middle estimate is 3.2-fold (0.50 log units) above the measured one; measured number below the stated range.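

Trifluoromethyl in place of bromo gives a 2.9-fold lower number from compound 3 to compound 4 (0.47 log units; beyond the scatter), so in this assay this change does not carry unchanged from the core of compound 1 to the core of compound 3: the same change on two cores in this assay, a 1.1-fold higher number (0.06 log units; within the scatter) from compound 1 to compound 2 and a 2.9-fold lower number (0.47 log units; beyond the scatter) from compound 3 to compound 4, 3.4-fold (0.53 log units) apart, beyond the scatter of two such steps. Trifluoromethyl in place of methyl likewise gives a 2.9-fold lower number from compound 2 to compound 4 (0.46 log units; beyond the scatter), and it also fails to carry from one core to the other: the same change on two cores in this assay, a 1.2-fold higher number (0.07 log units; within the scatter) from compound 1 to compound 3 and a 2.9-fold lower number (0.46 log units; beyond the scatter) from compound 2 to compound 4, 3.4-fold (0.53 log units) apart, beyond the scatter of two such steps. Within the data shown here, both steps end at compound 4, the only compound here carrying trifluoromethyl in both places, so the size of each step depends on the group at the other place, but a single compound shows neither why this happens nor how general it is.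

Left open is whether a chloro, nitrile or amine in place of either trifluoromethyl would also give a lower number. Also open, on these data alone, is whether the lower number of compound 4 would recur in another cell line or at another exposure time.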